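Ethynyl in Place of Methoxy on a Ring Carbon

The compounds below may be only part of what the source reports. "The series", "measured", "known", "first", "only" and "open" are said of these compounds alone.

Of the compounds shown here, two with a shared core have been tested in a functional assay on CHO cells for agonist activity at metabotropic glutamate receptor 5 (Homo sapiens), read by inositol phosphate accumulation; on this read-out higher numbers stand for weaker inhibition and lower numbers for stronger inhibition. Compound 1 `Cc1nc(C#Cc2ccc3[nH]ccc3c2)cs1` carries an indole-type bicyclic group at one end of the alkyne. In this assay compound 1 reaches only the limit > 10000 nM, which is a boundary of the measurement and not a number. Compound 2 `COc1ncccc1C#Cc1csc(C)n1` instead carries a six-membered aromatic ring with one nitrogen, bearing a methoxy group. In this assay, for the measured compounds named here, compound 2 gives 228 nM, the only true number in the set. The result for compound 1 is a limit. Compound 2 therefore stands alone as the single measured point.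

Compound 3 `C#Cc1ncccc1C#Cc1csc(C)n1` is the not yet measured partner of compound 2. The change is ethynyl in place of methoxy on an aromatic carbon. Going by the values given here, no measured pair shows this kind of swap, so its effect has to be estimated rather than read off. The step is expected to be small, within or just beyond the usual scatter, with no firm direction.

Compound 3 is therefore estimated to give 400 nM in this assay, in a range from 100 nM to 1500 nM. This estimate means an expected step of a 1.8-fold higher number from compound 2 to compound 3 (0.24 log units; within the scatter).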

Compound 3, half-maximal inhibitory concentration: 192 nM
Beside the measured number, compound 3's estimate is 2.1-fold (0.32 log units) above it; the range from low to high includes it.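

For the compounds shown here, until now this position had only one measured group, so nothing showed whether the methoxy could be exchanged at all. In this assay, putting ethynyl in place of methoxy gives a 1.2-fold lower number from compound 2 to compound 3 (0.07 log units; within the scatter), so at this aromatic carbon, next to the ring nitrogen and ortho to a group of 8 heavy atoms, the two groups of 2 heavy atoms cannot be told apart on this read-out, even though the oxygen leaves, the hydrogen-bond acceptor count of the group goes from 1 to 0, and a triple bond enters. No measurement shown here bears on what lies behind this result.

Going by these compounds, whether the same position would accept a quite different group, such as an amine, a carboxylic acid or a longer chain like butoxy, remains open, and a single pair cannot show how far this freedom extends. Also open, on these data alone, is whether a plain hydrogen at this carbon would give a similar number, which would show how much either group contributes to the read-out.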